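Swapping carbamoyl for fluoro: what to expect for compound 4

The compounds below may be only part of what the source reports. "The series", "measured", "known", "first", "only" and "open" are said of these compounds alone.

Within the data shown here, compound 3 `C[C@H](Nc1nc(N)nc(N)c1C#N)c1c(-c2ccccc2)c(=O)n2cc(F)ccc2c1-c1ccc(C(N)=O)cc1` gives 97% in an ADME assay on microsomes from liver (Mus musculus), read by LC-MS, using NADPH, with a stated time of 30 min, tested at 1 uM (on this read-out lower numbers stand for a less stable compound and higher numbers for a more stable compound), the highest of the three numbers so far. Compound 1 `Cc1c([C@H](C)Nc2nc(N)nc(N)c2C#N)c(-c2ccccc2)c(=O)n2cc(F)ccc12` gives 85% and compound 2 `C[C@H](Nc1nc(N)nc(N)c1C#N)c1c(-c2ccccc2)c(=O)n2cc(F)ccc2c1C1CC1` gives 87%; the step of a number 12 percentage points higher from compound 1 to compound 3 (beyond the scatter) lies beyond the scatter, whereas the step of a number 10 percentage points higher from compound 2 to compound 3 (within the scatter) lies within it. Compound 4 `C[C@H](Nc1nc(N)nc(N)c1C#N)c1c(-c2ccccc2)c(=O)n2cc(F)ccc2c1-c1ccc(F)cc1` differs from compound 3 by fluoro in place of carbamoyl on an aromatic carbon. Neither measured step touches that part of the molecule; both exchange the group on the shared core, so they bear only loosely on this change. Because compound 3 already stands at 97%, a small downward step or none beyond the scatter is expected: a number 9 percentage points lower from compound 3 to compound 4 (within the scatter). Compound 4 is therefore estimated at 88%, with a range from 72% to 98%.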

Compound 4, percent of the compound remaining: 83%
Beside the measured number, compound 4's estimate is 5 percentage points above it; measured number inside the range.
By their numbers in this assay, from the lowest: compounds 4, 1, 2 and 3 (each within the scatter of the next, the first and the last beyond it).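

Fluoro in place of carbamoyl gives a number 14 percentage points lower from compound 3 to compound 4 (beyond the scatter) in this assay and so shows that the group para to a large group on this aromatic ring matters here. An aromatic ring on the shared core is not enough to keep the higher number: 4-fluorophenyl gives a number 4 percentage points lower from compound 2 to compound 4 (within the scatter) against cyclopropyl and a number 2 percentage points lower from compound 1 to compound 4 (within the scatter) against methyl. Among these compounds, only the carbamoyl goes with a step beyond the scatter from compound 1. From the compounds shown here alone, whether an amine or a carboxylic acid in place of carbamoyl would hold the higher number stays open. Nothing shown gives a reason for this difference.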